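The source may hold more compounds than are shown below. What is called first, only, known or untested is meant among the compounds shown, and "the series" means these compounds.

Measured compounds:
compound 1 `Cc1nc(-c2ccc(F)cc2)c(C(=O)N2CCN(c3ccc(C(=O)C(C)C)cc3)CC2)o1`: "not active" (no number reported)
compound 2 `Cc1nc(-c2ccc(F)cc2)c(C(=O)N2CCN(c3ccc(Cl)cc3)CC2)o1`: "not active" (no number reported)
compound 3 `Cc1nc(-c2ccccc2)c(C(=O)N2CCN(c3cccc(F)c3)CC2)o1`: 45 nM

All three were run in a functional assay on HL-60 cells (Homo sapiens) for inhibition, read by MTT assay, with a stated time of 72 h; on this read-out higher numbers stand for weaker inhibition and lower numbers for stronger inhibition. Compound 1 stands with no number at all: in this assay compound 1 is recorded as "not active" (no number reported), and compound 2 shares that outcome, giving "not active" (no number reported). Only compound 3 returns a number, 45 nM, in this assay. Compound 1 and compound 2 carry the 4-fluorophenyl on the shared core; compound 3 carries the plain phenyl there and differs from both in the group on the piperazine as well, so no single-point comparison between measured compounds is available.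

Compound 4 `Cc1nc(-c2ccccc2)c(C(=O)N2CCN(c3ccc(C(=O)C(C)C)cc3)CC2)o1` is the next entry. It differs from compound 1 by hydrogen in place of fluoro on an aromatic carbon, so that, cut one bond further out, the 4-fluorophenyl of compound 1 becomes the phenyl of compound 3, while the piperazine substituent of compound 1 is kept.

Within the data shown here, with no measured step of this kind, the expected size is uncertain. Given that compound 1 gives "not active" (no number reported) and compound 3 gives 45 nM, some recovery of inhibition is expected for compound 4 in this assay, but well short of compound 3 and possibly again without a number. Compound 4 is estimated at 3000 nM, within 300 nM to 30000 nM.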

Compound 4, half-maximal inhibitory concentration: "not active" (no number reported)
Nothing numeric was reported for compound 4; there is nothing to compare the estimate with.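

In this assay compound 4 gives "not active" (no number reported) and compound 1 gives "not active" (no number reported) as well, so no new step can be read from this pair. The compounds shown leave open how the change from 4-fluorophenyl to phenyl acts on inhibition where a number can be read. No available evidence bears on this outcome.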